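Series notes: from compound 2 to compound 3

This account rests on a few compounds, and the source may have more. Where it says the series, first, only, none or still open, it means among the compounds named here.

Measured so far in a functional assay (B cells) with Mus musculus as the target; on this read-out lower numbers stand for an effect already at smaller amounts and higher numbers for an effect only at larger amounts of compound:
compound 1 `C=CCn1c(=O)n(C2CCC(CO)C2)c2nc(N)nc(O)c21` gives 226 uM
compound 2 `CN(C)CCCn1c(=O)n(C2OC(CO)[C@@H](O)[C@H]2O)c2nc(N)nc(O)c21` gives 194 uM

Compound 2 shows the lower of the two numbers, but compound 1 lies within the scatter of it, so the two are not separated. Compound 3 `Nc1nc(O)c2c(n1)n(C1OC(CO)[C@@H](O)[C@H]1O)c(=O)n2Cc1ccccc1` is not yet measured in this assay. It differs from compound 2 as follows: phenyl in place of 2-(dimethylamino)ethyl on a saturated chain carbon bound to an aromatic nitrogen. For the measured compounds named here, no step between measured compounds covers this change. Both measured values sit close together, and no step beyond the scatter is expected here. Compound 3 is therefore estimated at 200 uM, within 70 uM to 600 uM, an expected step of a 1.0-fold higher number from compound 2 to compound 3 (0.01 log units; within the scatter).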

Compound 3, concentration for half-maximal effect: 6 uM
For compound 3 the middle estimate is 33-fold (1.52 log units) above the measured one; measured number below the stated range.
By their numbers in this assay, from the lowest: compound 3; then compounds 2 and 1 (each within the scatter of the next).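

In this assay this position proves responsive: phenyl in place of 2-(dimethylamino)ethyl on a saturated chain carbon bound to an aromatic nitrogen gives a 32-fold lower number from compound 2 to compound 3 (1.51 log units; beyond the scatter), a large step where the earlier pair gave no separation. Nothing at hand bears on the reason for this step.

As far as these compounds go, whether the step follows from the aromatic ring entering or from the dimethylamino group leaving stays open. Equally open, from the compounds shown here alone, is how a saturated cyclohexyl ring, or a longer chain carrying phenyl, such as 2-phenylethyl, would read here.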